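The compounds below may be only part of what the source reports. "The series", "measured", "known", "first", "only" and "open" are said of these compounds alone.

Measured compounds:
compound 1, `C=Cc1cn2ncc(-c3ccnc(OC)c3)c2nc1NC`, 190 nM
compound 2, `COc1cc(-c2cnn3cc(OC)c(C4CCOC4)nc23)ccn1`, 1900 nM
compound 3, `COc1cn2ncc(-c3ccnc(OC(C)C)c3)c2nc1-c1cnn(C)c1`, 2300 nM

All three were tested in an assay on isolated protein for inhibition of activin receptor type-2A (Homo sapiens), read by 33P incorporation, with a stated time of 20 min, in the presence of a further agent that is not named here; a higher number here means a weaker inhibitor, a lower number a stronger inhibitor. Compound 2 stands second highest of the three numbers: its value lies within the usual scatter of that of compound 3, so the two cannot be ranked against each other, while compound 1 gives a lower number, and that gap lies beyond the scatter. No two of these compounds differ in only one place, so none of the steps between them can be attributed to a single change.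

The unmeasured compound 4, `COc1cc(-c2cnn3cc(OC)c([C@@H]4COC(C)(C)C4)nc23)ccn1`, is a close relative of compound 2. It differs in one place: a group of 7 heavy atoms (6 carbon, 1 oxygen; one five-membered non-aromatic ring with 1 hetero atom) in place of a group of 5 heavy atoms (4 carbon, 1 oxygen; one five-membered non-aromatic ring with 1 hetero atom), on an aromatic carbon

Nothing in the measured set shows what such a change does in this assay. The step of a 1.3-fold lower number from compound 2 to compound 4 (0.10 log units; within the scatter) is therefore expected to be small, with no direction that could be stated beyond the scatter. Compound 4 is estimated at 1500 nM, with a range from 400 nM to 6000 nM.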

Compound 4, half-maximal inhibitory concentration: 5300 nM
Compound 4: the middle estimate sits 3.5-fold (0.55 log units) below what was measured; the measured number falls inside the stated range.
By their numbers in this assay, from the lowest: compound 1; then compounds 2 and 3 (each within the scatter of the next); then compound 4.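

Among the compounds shown here, at the aromatic carbon ortho to a methoxy group, putting a group of 7 heavy atoms in place of oxolan-3-yl gives a 2.8-fold higher number from compound 2 to compound 4 (0.45 log units; beyond the scatter) in this assay, the first step in this set that can be traced to a single place. Both groups hold one five-membered non-aromatic ring with 1 hetero atom, 1 hydrogen-bond acceptor and no net charge, so the modest step goes with the added heavy atoms and the defined stereocentre, and this position is not indifferent to what sits on it. Nothing available explains the direction of the step.

The compounds shown cannot separate the added carbons from the stereocentre, and the mirror-image form of the entering group remains open. Going by these compounds, how a morpholine ring or a cyclopropyl group would behave at this carbon also stays unknown.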